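The source may report more compounds than this note shows. Statements on the series, on what has been measured and on what is new or still open speak of the compounds shown alone.

Compound 1 `Cn1cccc1-c1cc(-c2cccs2)nc(N)c1C#N` was examined in a functional assay on HOP-92 cells (Homo sapiens) for inhibition, read by sulforhodamine B assay, with a stated time of 48 h; on this read-out higher numbers stand for weaker inhibition of growth and lower numbers for stronger inhibition of growth. In this assay compound 1 reaches only a limit of the assay, > 100000 nM, as the limit of > 100000 nM in this assay, at which 1 of the 3 values shown sits, records. Compound 2 `Cn1cccc1-c1cc(-c2cccs2)[nH]c(=O)c1C#N` gives 10000 nM in this assay, and compound 3 `Cn1cccc1-c1cc(-c2ccccc2)[nH]c(=O)c1C#N` gives 110 nM. The change between them is phenyl in place of thiophen-2-yl on an aromatic carbon, which produced a 91-fold lower number from compound 2 to compound 3 (1.96 log units; beyond the scatter). Compound 4 `Cn1cccc1-c1cc(-c2ccccc2)nc(N)c1C#N` awaits measurement. It differs from compound 1 by phenyl in place of thiophen-2-yl on an aromatic carbon, the same kind of change; around the place, compound 1 carries an amino group (1 heavy atom) where compound 2 carries a group of 1 heavy atom. The difference between the two cores is not broken down here. With compound 1 giving only a limit, the expected step rests on a 91-fold lower number from compound 2 to compound 3 (1.96 log units; beyond the scatter) alone, and the expected step is an at least 20-fold lower number from compound 1 to compound 4 (1.30 log units; beyond the scatter). Compound 4 is expected to give about 5000 nM, estimated between 500 nM and 100000 nM.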

Compound 4, concentration for 50% growth inhibition: 10 nM
Estimate against measurement, compound 4: 500-fold (2.70 log units) above; measured number below the stated range.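

In this assay, phenyl in place of thiophen-2-yl gives an at least 10000-fold lower number from compound 1 to compound 4 (4.00 log units; beyond the scatter), so the number falls on both cores and the direction of the change carries over between them. The size does not carry over as a fixed amount, and the data do not show why the cores differ: the same change on two cores in this assay, a 91-fold lower number (1.96 log units; beyond the scatter) from compound 2 to compound 3 and an at least 10000-fold lower number (4.00 log units; beyond the scatter) from compound 1 to compound 4, at least 110-fold (2.04 log units) apart, beyond the scatter of two such steps. Compound 1 stands at a limit of the assay, so its step is only a bound and not a full size: the limit of > 100000 nM in this assay, at which 1 of the 4 values shown sits.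

The compounds shown leave open how other groups at this place would behave, such as methoxyphenyl, pyridinyl or cyclohexyl. They also leave open whether the same change would carry over to a third core.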